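Ethylsulfonyl for Ethyl on the Ring Nitrogen

The source may hold more compounds than are shown below. What is called first, only, known or untested is meant among the compounds shown, and "the series" means these compounds.

Among the compounds with values here, compound 2 `CCN1CCN(c2ccc(C#CC(C)(O)c3nccs3)cc2Nc2ncnc3[nH]ccc23)CC1` stands lowest of the two numbers so far in an assay for inhibition of mitogen-activated protein kinase kinase kinase 14 (Homo sapiens), read by luminescence and ADP-Glo, with a stated time of 120 min, in the presence of a further agent that is not named here (on this read-out higher numbers stand for weaker inhibition and lower numbers for stronger inhibition), giving 34.5 nM. Within the data shown here, compound 1 `CN(C)CCN(C)c1ccc(C#CC(C)(O)c2nccs2)cc1Nc1ncnc2[nH]ccc12`, in this assay, gives 484 nM, and the single measured step, a 14-fold lower number from compound 1 to compound 2 (1.15 log units; beyond the scatter), concerns a different part of the molecule, the substituent on the aromatic carbon. Compound 3 `CCS(=O)(=O)N1CCN(c2ccc(C#CC(C)(O)c3nccs3)cc2Nc2ncnc3[nH]ccc23)CC1` differs from compound 2 by ethylsulfonyl in place of ethyl on an amine nitrogen in a ring. Among the measured compounds shown here, no measured step touches this position, so there is nothing to weigh the change against, and the expectation rests on compound 2 alone with wide uncertainty. A step of a 3.5-fold higher number from compound 2 to compound 3 (0.54 log units; beyond the scatter) is expected, allowing for a loss that may or may not exceed the scatter. In this assay compound 3 is therefore estimated at 120 nM, within a range from 25 nM to 600 nM.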

Compound 3, half-maximal inhibitory concentration: 8.22 nM
Compound 3: middle estimate off by 15-fold (1.16 log units), on the high side; the whole stated range lies above it.
By their numbers in this assay, from the lowest: compound 3; then compound 2; then compound 1.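

Within the data shown here, at the amine nitrogen in the ring, the first measured change in this assay runs towards stronger inhibition: ethylsulfonyl in place of ethyl gives a 4.2-fold lower number from compound 2 to compound 3 (0.62 log units; beyond the scatter), a modest step, so this position accepts the larger group without a loss. Taken together with the change on the aromatic carbon, the 4-(ethylsulfonyl)piperazin-1-yl group gives a 59-fold lower number from compound 1 to compound 3 (1.77 log units; beyond the scatter), a large step that makes compound 3 the lowest of the three numbers. Nothing available here explains why the number fell at this position.

The compounds shown leave open whether the step depends on the sulfonyl link itself or also on the ethyl attached to it. A methylsulfonyl group, a cyclopropylsulfonyl group or an acetyl group on the same ring nitrogen would bear on that question.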